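Exchanging Cyclobutyl for a Dimethylaminopropyl Chain

This account rests on a few compounds, and the source may have more. Where it says the series, first, only, none or still open, it means among the compounds named here.

Compound 1 `CCc1ccccc1C(=O)Nc1c[nH]nc1C(=O)N[C@H]1CC[C@H](OC)CC1`: 3400 nM
Compound 2 `COc1cccc(OC)c1C(=O)Nc1c[nH]nc1C(=O)NC1CCC1`: > 50000 nM
Compound 3 `COc1cccc(OC)c1C(=O)Nc1c[nH]nc1C(=O)NC1CCN(C(=O)OC(C)(C)C)CC1`: > 50000 nM

In an ADME assay on MRC5 cells (Homo sapiens) for inhibition, with a stated time of 72 h (a higher number here means that more compound is needed for the effect, a lower number that less compound is needed), compound 1 gives 3400 nM. In this assay compound 2 reaches only a limit, > 50000 nM. Compound 3 also stands at a limit, > 50000 nM. Compound 2 thus sits at the limit of > 50000 nM in this assay, at which 2 of the 3 values shown sit, with no number of its own. Compound 4 `COc1cccc(OC)c1C(=O)Nc1c[nH]nc1C(=O)NCCCN(C)C` has not yet been measured; it differs from compound 2 in one place: 3-(dimethylamino)propyl in place of cyclobutyl on an amide-type nitrogen. For the measured compounds named here, no pair of measured compounds shares this change, so nothing measured sets the size of the step. The step of an at least 1.2-fold lower number from compound 2 to compound 4 (0.09 log units; that floor lies within the scatter) is expected to be small, likely none beyond the scatter, and with a fair chance of another limit. Compound 4 is expected at 40000 nM, in a range from 10000 nM to 60000 nM.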

Compound 4, half-maximal effective concentration: > 50000 nM
Compound 4: no number, only a limit; the forecaster's own chance of this, stated with the estimate: 60%; middle value at least 1.2-fold (0.09 log units) away from the limit.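

In this assay compound 4 reaches only a limit, > 50000 nM. For the compounds shown here, compound 2 also stands at a limit, so no step between the two can be read. On these data alone, whether 3-(dimethylamino)propyl in place of cyclobutyl changes the number at all stays open.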